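Cyclohexyl in Place of Chloro on a Fused Aromatic Core

The source may hold more compounds than are shown below. What is called first, only, known or untested is meant among the compounds shown, and "the series" means these compounds.

Compound 1 `CCS(=O)(=O)Nc1cc(F)cc2c1CCCC2c1c[nH]cn1` carries a fluoro on the aromatic ring of the shared core. In an assay on isolated protein (Cricetulus griseus) for binding affinity to Alpha-1B adrenergic receptor (Mesocricetus auratus), read by radioligand binding (on this read-out lower numbers stand for stronger inhibition and higher numbers for weaker inhibition), compound 1 gives < 10000 nM, which is a limit of the assay rather than a number. Compound 2 `CCS(=O)(=O)Nc1cc(Cl)cc2c1CCCC2c1c[nH]cn1` carries a chloro at the same position. In this assay compound 2 gives < 10000 nM, again only a limit. The step that the two limits leave unreadable from compound 1 to compound 2 therefore cannot be read, and compound 2 stands only at a limit, as does the other value shown, because both sit at the limit of < 10000 nM in this assay, at which 2 of the 2 values shown sit.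

Compound 3 `CCS(=O)(=O)Nc1cc(C2CCCCC2)cc2c1CCCC2c1c[nH]cn1` differs from compound 2 in one place: cyclohexyl in place of chloro on an aromatic carbon. For the measured compounds named here, no measured step bears on this change in a readable way, since the single step between compound 1 and compound 2 is hidden behind two limits. No direction and no size beyond the scatter can thus be taken from the measured pairs. Compound 3 is estimated at 1500 nM, with a range from 150 nM to 10000 nM. For compound 3 that estimate means an expected step that the limit leaves unreadable from compound 2 to compound 3.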

Compound 3, inhibition constant: 891 nM
Compound 3: middle estimate off by 1.7-fold (0.23 log units), on the high side; measured number inside the range.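

Compound 3 now has a measured number in this assay, but neither step leading to it, from compound 1 or from compound 2, can be read, because compound 1 and compound 2 stand only at a limit: the limit of < 10000 nM in this assay, at which 2 of the 3 values shown sit.

From the compounds shown here alone, whether cyclohexyl in place of chloro or fluoro on an aromatic carbon strengthens or weakens inhibition stays open.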